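Removing One Methyl from the Amide Side Chain

The source may report more compounds than this note shows. Statements on the series, on what has been measured and on what is new or still open speak of the compounds shown alone.

- Compound 1 `CCn1c(C(=O)N[C@@H](CC(=O)OC)C(=O)OC)ccc1C(CC)(CC)c1ccc(OCS(=O)(=O)c2ccccc2)c(C)c1` gives > 50000 nM as a limit
- Compound 2 `CCn1c(C(=O)NCCNC(=O)OC(C)(C)C)ccc1C(CC)(CC)c1ccc(OCS(=O)(=O)c2ccccc2)c(C)c1` gives > 50000 nM as a limit
- Compound 3 `CCn1c(C(=O)N[C@@H](C)CO)ccc1C(CC)(CC)c1ccc(OCS(=O)(=O)c2ccccc2)c(C)c1` gives 10800 nM as a number

Within the data shown here, in a functional assay on MCF7 cells (Homo sapiens) for antiproliferative activity, read by MTT assay, with a stated time of 24 h (a lower number here means a stronger inhibitor, a higher number a weaker inhibitor), compound 3 gives 10800 nM as the only true number here. Compound 1 and compound 2 report only a limit (the limit of > 50000 nM in this assay, at which 2 of the 3 values shown sit). Compound 4 `CCn1c(C(=O)NCCO)ccc1C(CC)(CC)c1ccc(OCS(=O)(=O)c2ccccc2)c(C)c1` differs from compound 3 by one change (hydrogen in place of methyl on a saturated chain carbon bound to an amide-type nitrogen and a saturated chain carbon): hydrogen in place of methyl on a saturated chain carbon bound to an amide-type nitrogen and a saturated chain carbon, so 1-(hydroxymethyl)ethyl becomes 2-hydroxyethyl. Among the measured compounds shown here, two measured steps bear on this group (an at least 4.6-fold lower number from compound 1 to compound 3 (0.66 log units; beyond the scatter)) and (an at least 4.6-fold lower number from compound 2 to compound 3 (0.66 log units; beyond the scatter)), but both exchange the whole group. For this smaller change, no step beyond the scatter is expected in this assay. The expected step (a 1.1-fold higher number from compound 3 to compound 4 (0.05 log units; within the scatter)) is therefore small. Compound 4 is estimated at 12000 nM (expected range 6000 nM to 30000 nM).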

Compound 4, half-maximal inhibitory concentration: 15500 nM
Estimate against measurement, compound 4: 1.3-fold (0.11 log units) below, and the stated range covers the measured number.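

In this assay, the methyl on a saturated chain carbon bound to an amide-type nitrogen and a saturated chain carbon can be replaced by hydrogen with only a 1.4-fold higher number from compound 3 to compound 4 (0.16 log units; within the scatter), so 2-hydroxyethyl and 1-(hydroxymethyl)ethyl read alike here. The simpler chain also stands clear of both earlier groups, with an at least 3.2-fold lower number from compound 2 to compound 4 (0.50 log units; beyond the scatter) and an at least 3.2-fold lower number from compound 1 to compound 4 (0.50 log units; beyond the scatter). Those two steps start from a limit and give only a smallest size: the limit of > 50000 nM in this assay, at which 2 of the 4 values shown sit.

As far as these compounds go, what an amine or a carboxylic acid in place of the hydroxy would give remains open. So does the effect of a longer chain.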